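The compounds below may be only part of what the source reports. "The series", "measured", "known", "first", "only" and "open" are said of these compounds alone.

Measured so far in a functional assay on A549 cells (Homo sapiens) for inhibition, read by MTT assay, with a stated time of 48 h; on this read-out lower numbers stand for stronger inhibition and higher numbers for weaker inhibition:
compound 1 `C/C(=N\NC(=O)c1cc(-c2ccc(Cl)cc2)nn1Cc1ccc(C(C)(C)C)cc1)c1cc(C)ccc1O` – 2490 nM
compound 2 `COc1ccc(-c2cc(C(=O)N/N=C(\C)c3cc(C)ccc3O)n(Cc3ccc(C(C)(C)C)cc3)n2)cc1` – 10400 nM

For the measured compounds named here, compound 2 stands at the highest of the two numbers in this assay; its nearest neighbour is compound 1, and the only single change measured is a 4.2-fold higher number from compound 1 to compound 2 (0.62 log units; beyond the scatter).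

Compound 3 `COc1ccc(-c2cc(C(=O)N/N=C(\C)c3cc(Cl)cc(Cl)c3O)n(Cc3ccc(C(C)(C)C)cc3)n2)cc1` is not yet measured. It differs from compound 2 by 3,5-dichloro-2-hydroxyphenyl in place of 2-hydroxy-5-methylphenyl on a carbon with a double bond to nitrogen. Going by the values given here, no measured step touches this part of the structure: the one step recorded concerns the substituent on the other aromatic ring, so it gives no direct guide to the size or direction here. With nothing to lean on, no step beyond the scatter is assumed, and the number for compound 3 is expected to stay near that of compound 2, with a wide band to reflect the absence of precedent.

Compound 3 is estimated at 8000 nM, in the range 2500 nM to 25000 nM. The estimated step is a 1.3-fold lower number from compound 2 to compound 3 (0.11 log units; within the scatter), expected to lie within the scatter.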

Compound 3, half-maximal inhibitory concentration: 2080 nM
Beside the measured number, compound 3's estimate is 3.8-fold (0.59 log units) above it, outside the stated range (below it).
By their numbers in this assay, from the lowest: compounds 3 and 1 (each within the scatter of the next); then compound 2.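

In this assay, for the compounds shown here, the aryl group on the carbon with a double bond to nitrogen proves able to move the number: 3,5-dichloro-2-hydroxyphenyl in place of 2-hydroxy-5-methylphenyl gives a 5.0-fold lower number from compound 2 to compound 3 (0.70 log units; beyond the scatter) and is the first measured step at this part of the structure. The series now has two places where a single change reaches beyond the scatter, the other being methoxy in place of chloro on an aromatic carbon, which gives a 4.2-fold higher number from compound 1 to compound 2 (0.62 log units; beyond the scatter) in the opposite direction. Nothing measured here accounts for the size or direction of the new step.

This change removes a methyl group and adds two chlorines together, so the part played by each stays unresolved. On these data alone, a 3-chloro-2-hydroxyphenyl or 5-chloro-2-hydroxyphenyl group would separate them, and the effect of the dichloro group with chloro in place of methoxy on the other aromatic ring remains open.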